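Aryl thioether variation and nucleoside transporter binding

The compounds below may be only part of what the source reports. "The series", "measured", "known", "first", "only" and "open" are said of these compounds alone.

Measured compounds:
compound 1 `Cc1cc(C)c(SCc2ncnc3c2ncn3[C@@H]2O[C@H](CO)[C@@H](O)[C@H]2O)c(C)c1` with 33100 nM
compound 2 `OC[C@H]1O[C@@H](n2cnc3c(CSc4ccccc4Br)ncnc32)[C@H](O)[C@@H]1O` with 2400 nM
compound 3 `OC[C@H]1O[C@@H](n2cnc3c(CSc4ccccc4F)ncnc32)[C@H](O)[C@@H]1O` with 355 nM

In an assay on isolated protein for binding affinity to Equilibrative nucleoside transporter 1 (Homo sapiens) (a lower number here means a stronger inhibitor, a higher number a weaker inhibitor), compound 3 stands at the low end of the three numbers: it lies a 6.8-fold lower number from compound 2 to compound 3 (0.83 log units; beyond the scatter) and a 93-fold lower number from compound 1 to compound 3 (1.97 log units; beyond the scatter). Compound 4 `OC[C@H]1O[C@@H](n2cnc3c(CSc4ccc(Cl)c(Cl)c4)ncnc32)[C@H](O)[C@@H]1O` has not been measured. It differs from compound 3 in one place: 3,4-dichlorophenyl in place of 2-fluorophenyl on a sulfur. Among the compounds with values here, all three measured steps concern the same aryl group on that sulfur, and each moved this assay beyond the scatter, with the single change a 6.8-fold lower number from compound 2 to compound 3 (0.83 log units; beyond the scatter) being the only one that kept the group's substitution pattern while swapping the halogen. Within the data shown here, no measured pair shows chlorine, nor a group substituted in the manner of 3,4-dichlorophenyl, so the direction for compound 4 rests on the observation that every departure from 2-fluorophenyl among the measured compounds raised the number. Compound 4 is therefore expected to bind more weakly than compound 3, a step of a 4.2-fold higher number from compound 3 to compound 4 (0.63 log units; beyond the scatter), with an estimated value of 1500 nM and a plausible range from 250 nM to 9000 nM.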

Compound 4, half-maximal inhibitory concentration: 224 nM
The estimate for compound 4 lay 6.7-fold (0.83 log units) above the measured number, outside the stated range (below it).
By their numbers in this assay, from the lowest: compounds 4 and 3 (each within the scatter of the next); then compound 2; then compound 1.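

In this assay, within the data shown here, the step of a 1.6-fold lower number from compound 3 to compound 4 (0.20 log units; within the scatter) is the first departure from 2-fluorophenyl on this sulfur that does not clearly raise the number, so 2-fluorophenyl is no longer the only aryl group at the low end of the series. The entering group has two chlorines and one more heavy atom, yet that change leaves the number within the scatter. The aryl group still matters, as the steps of an 11-fold lower number from compound 2 to compound 4 (1.03 log units; beyond the scatter) and a 150-fold lower number from compound 1 to compound 4 (2.17 log units; beyond the scatter) both lie beyond the scatter.

Nothing measured here explains why these aryl groups differ. Still open, going by these compounds, is whether a phenyl with a single chlorine would match compound 4 and how an amine or a carboxylic acid on the aryl group would fare.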